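A bromo to methoxy step in a small series

The source may hold more compounds than are shown below. What is called first, only, known or untested is meant among the compounds shown, and "the series" means these compounds.

Compound 1 `Nc1c(C2=NCCN2)cnn1-c1ccc(F)cc1` gives > 500000 nM as a limit.
Compound 2 `Nc1c(C2=NCCN2)cnn1-c1ccc(Br)cc1` gives > 500000 nM as a limit.

In an ADME assay on Vero cells (Chlorocebus sabaeus) for cytotoxicity, read by CellTiter-Glo and ATP content, with a stated time of 72 h (on this read-out higher numbers stand for lower toxicity in this test and lower numbers for higher toxicity in this test), compound 2 stands at > 500000 nM and this is a limit and not a number. Among the measured compounds shown here, the same holds for its only measured neighbour, and the record so far is the limit of > 500000 nM in this assay, at which 2 of the 2 values shown sit, with no number yet read. Compound 3 (`COc1ccc(-n2ncc(C3=NCCN3)c2N)cc1`) carries methoxy in place of bromo on an aromatic carbon, on a six-membered aromatic ring of carbon only, para to a large group (methoxy in place of bromo on an aromatic carbon). For the measured compounds named here, only the step that the two limits leave unreadable from compound 1 to compound 2 bears on this change, and it gives no size, so no step beyond the scatter is expected in this assay in either direction. An expected step that the limit leaves unreadable from compound 2 to compound 3 is estimated here. For compound 3 the estimate is 700000 nM with an expected range from 300000 nM to 1500000 nM in all.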

Compound 3, half-maximal cytotoxic concentration: > 500000 nM
Compound 3 was reported as a limit; the forecaster's own chance of this, stated with the estimate: 80%; the middle value is on the limit's open side.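

Compound 3 is reported as a limit, > 500000 nM, in this assay, so no new step can be read from compound 1 or compound 2 to compound 3: the limit of > 500000 nM in this assay, at which 3 of the 3 values shown sit.

The compounds shown leave open where the actual values of compound 1, compound 2 and compound 3 lie, and whether fluoro, bromo and methoxy differ at all in this assay.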